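Removing Trifluoromethyl From the Benzyl Group of Compound 3

A few compounds are considered here, and "the series" means these few. Any claim that something is new, unique, unknown or untested is made for them only; others in the source may bear on it.

Compound 3 `COc1cccc(CNCCCNc2ccnc3cc(Cc4cccc(C(F)(F)F)c4)ccc23)c1O` gives 1720 nM in an ADME assay on HepG2 cells (Homo sapiens) for cytotoxicity, read by luminescence, CellTiter-Glo and ATP content, with a stated time of 72 h; on this read-out higher numbers stand for an effect only at larger amounts of compound and lower numbers for an effect already at smaller amounts. For the measured compounds named here, that is the highest of the three numbers so far, though compound 1 `COc1ccc(-c2ccc3c(NCCCNCc4cccc(OC)c4O)ccnc3c2)cc1`, which gives 1600 nM, lies within the scatter of it (a 1.1-fold higher number from compound 1 to compound 3 (0.03 log units; within the scatter)), while compound 2 `COc1cccc(CNCCCNc2ccnc3cc(-c4ccc(C(C)(C)C)cc4)ccc23)c1O` gives 690 nM, a gap beyond the scatter (a 2.5-fold higher number from compound 2 to compound 3 (0.40 log units; beyond the scatter)). Compound 4 `COc1cccc(CNCCCNc2ccnc3cc(Cc4ccccc4)ccc23)c1O` has not yet been measured in this assay. It differs from compound 3 in one place: hydrogen in place of trifluoromethyl on an aromatic carbon. Going by the values given here, no measured step removes a group in quite this way. The nearest comparison is a 2.3-fold lower number from compound 1 to compound 2 (0.37 log units; beyond the scatter), an exchange of one group for another on an aromatic carbon that gave only a modest step. The two steps that replace the whole group, a 1.1-fold higher number from compound 1 to compound 3 (0.03 log units; within the scatter) and a 2.5-fold higher number from compound 2 to compound 3 (0.40 log units; beyond the scatter), were modest at most. Compound 4 is therefore expected to show a step of a 1.1-fold lower number from compound 3 to compound 4 (0.06 log units; within the scatter), not beyond the scatter. The estimate for compound 4 in this assay is 1500 nM, with a range from 700 nM to 3300 nM.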

Compound 4, half-maximal effective concentration: 5720 nM
The estimate for compound 4 lay 3.8-fold (0.58 log units) below the measured number; measured number outside the range, above it.
By their numbers in this assay, from the lowest: compound 2; then compounds 1 and 3 (each within the scatter of the next); then compound 4.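

In this assay, trifluoromethyl on the benzyl group counts for more than the earlier exchange of the whole group suggested: removing it gives a 3.3-fold higher number from compound 3 to compound 4 (0.52 log units; beyond the scatter), whereas the change of the whole group gave a 1.1-fold higher number from compound 1 to compound 3 (0.03 log units; within the scatter). Plain benzyl also stands apart from the other two groups at this position, with a 3.6-fold higher number from compound 1 to compound 4 (0.55 log units; beyond the scatter) and an 8.3-fold higher number from compound 2 to compound 4 (0.92 log units; beyond the scatter), so compound 4 shows its effect only at larger amounts than any of the three earlier compounds. Nothing available accounts for this step.

From the compounds shown here alone, what stays open is whether the higher number of compound 4 is tied to trifluoromethyl itself or would also shift with a chlorine atom or a nitrile in the same place. Going by these compounds, it is equally open whether an amine on the benzyl group would move the number the same way.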